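Extending the chain beyond compound 3

A few compounds are considered here, and "the series" means these few. Any claim that something is new, unique, unknown or untested is made for them only; others in the source may bear on it.

Three urea-linked compounds have been tested in an ADME assay on the whole organism for cytotoxicity, with Artemia salina as the target, with a stated time of 24 h; a lower number here means that less compound is needed, a higher number that more compound is needed for the effect. Compound 1 `Cc1ccc(S(=O)(=O)NC(=O)Nc2ccccc2C(=O)/C=C/c2cccc(O)c2)cc1` gives 39.3 ug/mL, compound 2 `COc1cc(/C=C/C(=O)c2ccccc2NC(=O)NS(=O)(=O)c2ccc(C)cc2)ccc1O` gives 17.8 ug/mL, and compound 3 `Cc1ccc(S(=O)(=O)NC(=O)Nc2ccccc2C(=O)/C=C/c2cccc(F)c2)cc1` gives 4.13 ug/mL, the lowest of the three numbers. The steps among them, a 2.2-fold lower number from compound 1 to compound 2 (0.34 log units; beyond the scatter), a 9.5-fold lower number from compound 1 to compound 3 (0.98 log units; beyond the scatter) and a 4.3-fold lower number from compound 2 to compound 3 (0.63 log units; beyond the scatter), all concern substituents on the aromatic ring at the end of the chain, and each was modest.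

Compound 4 `Cc1ccc(S(=O)(=O)NC(=O)Nc2ccccc2C(=O)/C=C/C=C/c2ccccc2)cc1` changes something different: 2-phenylethenyl in place of 3-fluorophenyl on a double-bonded chain carbon bound to a double-bonded chain carbon. Among the measured compounds shown here, no measured step swaps the ring itself for a longer chain, so the three known steps bear only indirectly on this change. What they do show is that the lowest number belongs to the fluorine-bearing compound 3, and compound 4 no longer carries fluorine; the compounds without it, compound 1 and compound 2, give higher numbers. The step is therefore expected to be a 2.9-fold higher number from compound 3 to compound 4 (0.46 log units; beyond the scatter), with wide uncertainty. Compound 4 is estimated at 12 ug/mL, within a range from 3 ug/mL to 45 ug/mL.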

Compound 4, concentration for half-maximal effect: 18.2 ug/mL
Beside the measured number, compound 4's estimate is 1.5-fold (0.18 log units) below it, within the range that was stated.
By their numbers in this assay, from the lowest: compound 3; then compounds 2 and 4 (each within the scatter of the next); then compound 1.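

At this place, on a double-bonded chain carbon bound to a double-bonded chain carbon, the longer 2-phenylethenyl group is tolerated in this assay, but it does not match 3-fluorophenyl: the change gives a 4.4-fold higher number from compound 3 to compound 4 (0.64 log units; beyond the scatter) and so loses part of what compound 3 gained. Set against the ring-bearing compounds without fluoro, the same group gives a 2.2-fold lower number from compound 1 to compound 4 (0.33 log units; beyond the scatter), whereas a 1.0-fold higher number from compound 2 to compound 4 (0.01 log units; within the scatter) leaves the two numbers level, so an unsubstituted longer chain sits among these compounds rather than outside their range. Nothing available explains these differences.

Still open, going by these compounds, is whether 2-(3-fluorophenyl)ethenyl, which combines the fluoro group with the longer chain, would give a number closer to that of compound 3 or compound 4. Also open, on these data alone, is how an amine or a carboxylic acid on the end ring would behave at this place.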